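The source may hold more compounds than are shown below. What is called first, only, known or untested is meant among the compounds shown, and "the series" means these compounds.

Compound 1 `CSc1ncnc2c1c(-c1ccccc1)cn2[C@@H]1O[C@H](CO)[C@@H](O)[C@H]1O`: > 20000 nM
Compound 2 `CNc1ncnc2c1c(-c1cccs1)cn2[C@@H]1O[C@H](CO)[C@@H](O)[C@H]1O`: > 20000 nM

In a functional assay on K562 cells (Homo sapiens), read by MTT assay, with a stated time of 72 h (a lower number here means a stronger inhibitor, a higher number a weaker inhibitor), compound 1 gives only a limit of the assay, > 20000 nM. Compound 2 likewise gives only a limit, > 20000 nM. It stands at the limit of > 20000 nM in this assay, at which 2 of the 2 values shown sit, so no measured number is known for it. Compound 3 `CSc1ncnc2c1c(-c1cccs1)cn2[C@@H]1O[C@H](CO)[C@@H](O)[C@H]1O` differs from compound 2 by methylsulfanyl in place of methylamino on an aromatic carbon. Among the compounds with values here, no step between two measured compounds is known, so the size of this change cannot be read from the data. Compound 1, which carries the same methylsulfanyl group, also sits at the limit with > 20000 nM. Compound 3 is expected to remain at the limit, with a step that the limit leaves unreadable from compound 2 to compound 3 that means no change beyond the scatter. Compound 3 is estimated at 30000 nM, with a range from 10000 nM to 100000 nM.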

Compound 3, half-maximal inhibitory concentration: > 20000 nM
Compound 3 ended at the assay's limit; the forecaster's own chance of this, stated with the estimate: 85%; the middle value does not contradict the limit.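

Within the data shown here, compound 3 gives only a limit of the assay, > 20000 nM, so no step from compound 1 or compound 2 to it can be read. The compounds shown leave open whether methylsulfanyl in place of methylamino, or thiophen-2-yl in place of phenyl, changes potency at all.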